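A few compounds are considered here, and "the series" means these few. Any claim that something is new, unique, unknown or untested is made for them only; others in the source may bear on it.

Compound 1 `CCN1CCCC1CNC(=O)c1cc(NS(=O)(=O)N(C)C)c(C)cc1OC`, in a functional assay on the whole organism for inhibition, with Mus musculus as the target; on this read-out higher numbers stand for an effect only at larger amounts of compound and lower numbers for an effect already at smaller amounts: 13.3 mg/kg.
Compound 2 `CCN1CCCC1CNC(=O)c1cc(NS(=O)(=O)N(C)C)c(Cl)cc1OC`, in this assay: 8.3 mg/kg.

Compound 2 gives the lower of the two numbers, but a 1.6-fold lower number from compound 1 to compound 2 (0.20 log units; within the scatter) lies within the scatter, so the two are not separated. Compound 3 `CCN1CCCC1CNC(=O)c1cc(N(C)S(=O)(=O)N(C)C)c(Cl)cc1OC` carries methyl in place of hydrogen on a sulfonamide nitrogen. Within the data shown here, no measured step touches the sulfonamide nitrogen; the single step known, chloro in place of methyl on an aromatic carbon, stayed within the scatter. Nothing in the series supports a step beyond the scatter in either direction, and the range given is wide for that reason. Compound 3 is expected at 12 mg/kg, between 4 mg/kg and 40 mg/kg. The step of a 1.4-fold higher number from compound 2 to compound 3 (0.16 log units; within the scatter) is accordingly expected to stay within the scatter.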

Compound 3, dose for half-maximal effect: 31.8 mg/kg
Beside the measured number, compound 3's estimate is 2.7-fold (0.42 log units) below it, within the range that was stated.
By their numbers in this assay, from the lowest: compounds 2 and 1 (each within the scatter of the next); then compound 3.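

In this assay, among these compounds, the step of a 3.8-fold higher number from compound 2 to compound 3 (0.58 log units; beyond the scatter) is the first to lie beyond the scatter, so the sulfonamide nitrogen is a place where a change separates two compounds, which the aromatic carbon change did not do. Replacing hydrogen with methyl there moves the number towards larger doses. Nothing available bears on the reason for this shift. Still open, going by these compounds, is how ethyl or a longer chain on the sulfonamide nitrogen would read. Also open, on these data alone, is whether the methyl step holds with methyl instead of chloro on the aromatic carbon.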